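Chalcone Amides: From Methoxyphenyl to Furyl

A few compounds are considered here, and "the series" means these few. Any claim that something is new, unique, unknown or untested is made for them only; others in the source may bear on it.

compound 1 `CC(Br)C(=O)Nc1ccc(C(=O)/C=C/c2ccc(Cl)cc2)cc1`: 59%
compound 2 `COc1ccc(/C=C/C(=O)c2ccc(NC(=O)C(C)Br)cc2)cc1`: 40%

Of the compounds shown here, two have been measured in a functional assay on the whole organism (strain albino) for inhibition, with Rattus norvegicus as the target, read by paw edema, with stated times of 30 min and 3 h, at a dose of 100 mg/kg by the oral route; a lower number here means less inhibition, a higher number more inhibition at the dose given (going by the name of the read-out): compound 1 gives 59%, and compound 2 gives 40%. Compound 2 stands lowest of the two numbers, with compound 1 the nearest neighbour above it. Going by the values given here, the one measured step, a number 19 percentage points lower from compound 1 to compound 2 (beyond the scatter), concerns the exchange of chloro for methoxy and does not touch the group replaced here. Compound 3 `CC(Br)C(=O)Nc1ccc(C(=O)/C=C/c2ccco2)cc1` differs from compound 2 by furan-2-yl in place of 4-methoxyphenyl on a double-bonded chain carbon bound to a double-bonded chain carbon. Among the compounds with values here, no measured step bears directly on this change; the only comparison available shows that the read-out moved modestly when the ring substituent was varied. The step of a number 7 percentage points higher from compound 2 to compound 3 (within the scatter) is therefore expected to be small, without a clear direction beyond the scatter. Compound 3 is estimated at 47% in this assay, within a range from 30% to 65%.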

Compound 3, a percentage reported as inhibition, in the whole organism at one dose (the size of the read-out at that dose, not a potency): 42%
For compound 3 the middle estimate is 5 percentage points above the measured one, and the stated range covers the measured number.
By their numbers in this assay, from the lowest: compounds 2 and 3 (each within the scatter of the next); then compound 1.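

In this assay, the step of a number 2 percentage points higher from compound 2 to compound 3 (within the scatter) shows that furan-2-yl, with 5 heavy atoms, and 4-methoxyphenyl, with 8, cannot be told apart on this double-bonded chain carbon. The same furan-2-yl set against 4-chlorophenyl gives a number 17 percentage points lower from compound 1 to compound 3 (beyond the scatter), so among these three compounds, compound 1 stands apart, while compound 2 and compound 3 do not, even though compound 2 keeps a six-membered aromatic ring of carbon only. No available evidence bears on this result.

From the compounds shown here alone, it remains open how an amine or a carboxylic acid on the aromatic ring at this place would affect the inhibition read-out. Also open, going by these compounds, is whether a thiophene ring, with sulfur in place of the furan oxygen, would stay within the scatter of compound 3.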